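A few compounds are considered here, and "the series" means these few. Any claim that something is new, unique, unknown or untested is made for them only; others in the source may bear on it.

In a functional assay on DU-145 cells (Homo sapiens) for antiproliferative activity, read by WST assay, with a stated time of 3 days (on this read-out lower numbers stand for stronger inhibition and higher numbers for weaker inhibition), compound 1 `CCOc1c(-c2cc(OC)c(OC)c(OC)c2)oc2ccccc2c1=O` gives 6200 nM and compound 2 `CCN(CC)CCCCOc1c(-c2cc(OC)c(OC)c(OC)c2)oc2ccccc2c1=O` gives 13300 nM as the higher of the two numbers, which makes compound 2 the weaker inhibitor of this pair. Compound 3 `CCCN(CCC)CCCOc1c(-c2cc(OC)c(OC)c(OC)c2)oc2ccccc2c1=O` differs from compound 2 by one change (dipropylamino in place of (diethylamino)methyl on a saturated chain carbon, three bonds along the chain from an oxygen on an aromatic ring) with dipropylamino in place of (diethylamino)methyl on a saturated chain carbon. Among the compounds with values here, the only measured step bearing on this is a 2.1-fold higher number from compound 1 to compound 2 (0.33 log units; beyond the scatter) and that modest step put the whole 2-(diethylamino)ethyl group in place of hydrogen. A swap within that amine-bearing chain should count for no more, so the expected change is only a 1.1-fold lower number from compound 2 to compound 3 (0.04 log units; within the scatter) and no step beyond the scatter is anticipated. For this assay compound 3 is estimated at 12000 nM with 6000 nM to 24000 nM as its likely range.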

Compound 3, half-maximal inhibitory concentration: > 50000 nM
Compound 3 ended at the assay's limit; the forecaster's own chance of this, stated with the estimate: 5%; at least 4.1-fold (0.61 log units) between middle value and limit.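

The amine end of this chain matters more than the first step suggested: exchanging (diethylamino)methyl for dipropylamino gives an at least 3.7-fold higher number from compound 2 to compound 3 (0.57 log units; beyond the scatter). Putting (dipropylamino)methyl in place of hydrogen on the chain gives an at least 8.0-fold higher number from compound 1 to compound 3 (0.90 log units; beyond the scatter). The reading for compound 3 is a limit of the assay, not a number: the limit of > 50000 nM in this assay, at which 1 of the 3 values shown sits.

This one change alters both the chain and the groups on the nitrogen, and the compounds shown do not separate the two. Going by these compounds, how a 3-(diethylamino)propyl chain or a piperidine at the chain end would read remains open.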